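A few compounds are considered here, and "the series" means these few. Any claim that something is new, unique, unknown or untested is made for them only; others in the source may bear on it.

Compound 1 `Cc1ccc(C2(CNC(=O)Nc3c(C(C)C)cccc3C(C)C)CCCC2)cc1`: 25 nM
Compound 2 `CC(C)c1cccc(C(C)C)c1NC(=O)NCC1(c2ccc(C(F)(F)F)cc2)CCCC1`: 66 nM
Compound 3 `CC(C)c1cccc(C(C)C)c1NC(=O)NCC1(c2ccc(N)cc2)CCCC1`: 29 nM

In an assay on microsomes for inhibition of acyl-CoA:cholesterol acyltransferase (Oryctolagus cuniculus) (on this read-out higher numbers stand for weaker inhibition and lower numbers for stronger inhibition), compound 3 gives the second highest of the three numbers; it lies within the scatter of compound 1 and differs from compound 2 by a 2.3-fold lower number from compound 2 to compound 3 (0.36 log units; beyond the scatter). Compound 4 `CC(C)c1cccc(C(C)C)c1NC(=O)NCC1(c2ccc(CO)cc2)CCCC1` has not yet been measured. Compound 4 carries hydroxymethyl in place of amino on an aromatic carbon. Among the compounds with values here, no measured step makes this exact change, but three steps at the same aromatic carbon bear on it: a 1.2-fold higher number from compound 1 to compound 3 (0.06 log units; within the scatter), a 2.6-fold higher number from compound 1 to compound 2 (0.42 log units; beyond the scatter) and a 2.3-fold lower number from compound 2 to compound 3 (0.36 log units; beyond the scatter). Amino in place of methyl leaves the number within the scatter, while trifluoromethyl raises it modestly and amino in place of trifluoromethyl lowers it by a similar modest amount. Every group tried at this position has kept compound 1, compound 2 and compound 3 within a narrow band, so hydroxymethyl is expected to move the number little or not beyond the scatter, with a slightly higher number the more likely direction if anything shifts. The expected step from compound 3 to compound 4 is a 1.4-fold higher number from compound 3 to compound 4 (0.14 log units; within the scatter). Compound 4 is therefore estimated to give 40 nM in this assay, within a range from 15 nM to 110 nM.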

Compound 4, half-maximal inhibitory concentration: 26 nM
The estimate for compound 4 lay 1.5-fold (0.19 log units) above the measured number; measured number inside the range.
By their numbers in this assay, from the lowest: compounds 1, 4 and 3 (each within the scatter of the next); then compound 2.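

In this assay, hydroxymethyl in place of amino gives a 1.1-fold lower number from compound 3 to compound 4 (0.05 log units; within the scatter) and hydroxy in place of hydrogen on the saturated chain carbon gives a 1.0-fold higher number from compound 1 to compound 4 (0.02 log units; within the scatter), so adding the oxygen to the methyl of compound 1 leaves no readable change, and compound 1, compound 3 and compound 4 cannot be told apart. Within the data shown here, the same group in place of trifluoromethyl gives a 2.5-fold lower number from compound 2 to compound 4 (0.40 log units; beyond the scatter), a step close in size to the one from compound 2 to compound 3, which leaves compound 2 as the only one of the four compounds standing apart at this aromatic carbon and the one with the weakest inhibition. Nothing available accounts for why trifluoromethyl alone separates from methyl, amino and hydroxymethyl here.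

The compounds shown leave open whether this shared level would hold for a carboxylic acid, a longer chain such as hydroxyethyl, or a methoxymethyl group on the same carbon. They also leave open whether a single fluorine or a chlorine would read with compound 2 or with the other three.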